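Sulfonamide series: pyridine substituent swap from aryl to carbamoyl

The source may hold more compounds than are shown below. What is called first, only, known or untested is meant among the compounds shown, and "the series" means these compounds.

Measured so far:
compound 1 `COc1ccc(Cl)cc1S(=O)(=O)Nc1cncc(-c2ccccc2C)c1` 178 nM
compound 2 `COc1ccc(S(=O)(=O)Nc2cccnc2)c(OC)c1` 10300 nM
compound 3 `COc1ccc(C(F)(F)F)cc1S(=O)(=O)Nc1cccnc1` 183 nM

In an assay on isolated protein for inhibition of alkaline phosphatase, tissue-nonspecific isozyme (Homo sapiens) (a higher number here means a weaker inhibitor, a lower number a stronger inhibitor), compound 1 sits at the low end of the three numbers, together with compound 3, whose value lies within the scatter of it; compound 2 stands far higher, well beyond the scatter. Among the compounds with values here, no single-point step between measured compounds is available.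

Compound 4 `COc1ccc(Cl)cc1S(=O)(=O)Nc1cncc(C(N)=O)c1` is not yet measured. It differs from compound 1 as follows: carbamoyl in place of 2-methylphenyl on an aromatic carbon. Carbamoyl in place of 2-methylphenyl shrinks the group on the pyridine ring considerably, and nothing among the measured compounds shows how this assay responds to such a change.

A step upward, beyond the scatter, is expected for a 5.1-fold higher number from compound 1 to compound 4 (0.70 log units; beyond the scatter). Compound 4 is estimated at 900 nM, within a range of 200 nM to 4000 nM.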

Compound 4, half-maximal inhibitory concentration: 16 nM
Compound 4: middle estimate off by 56-fold (1.75 log units), on the high side, outside the stated range (below it).
By their numbers in this assay, from the lowest: compound 4; then compounds 1 and 3 (each within the scatter of the next); then compound 2.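

At this aromatic carbon, two atoms from the ring nitrogen, 2-methylphenyl is not required for potency in this assay: carbamoyl in its place gives an 11-fold lower number from compound 1 to compound 4 (1.05 log units; beyond the scatter). Within the data shown here, the position therefore accepts a much smaller group with a hydrogen-bond donor and acceptor, and the number improves; the earlier compounds offered no step at this position. Nothing shown explains the gain.

Still open, on these data alone, is whether a methyl amide, a carboxylic acid or a nitrile at this carbon would keep the gain. How an amine or a longer chain would fare there is also unknown.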